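A few compounds are considered here, and "the series" means these few. Any claim that something is new, unique, unknown or untested is made for them only; others in the source may bear on it.

The measured compounds:

Compound 1 (`CC(C)(C)c1ccc(Cn2cc(-c3cn([C@H]4C[C@H](O)[C@@H](CO)O4)c(=O)[nH]c3=O)nn2)cc1`), which in a functional assay on MDA-MB-231 cells (Homo sapiens) for cytotoxicity, read by sulforhodamine B assay, tested at 10 uM (on this read-out higher numbers stand for more inhibition at the one concentration tested (going by the name of the read-out) and lower numbers for less inhibition), gives 106%.
Compound 2 (`CCCCCCCCc1cc(-c2cn([C@H]3C[C@H](O)[C@@H](CO)O3)c(=O)[nH]c2=O)on1`), which in this assay gives 96.7%.
Compound 3 (`CC(=O)OC[C@H]1O[C@@H](n2cc(-c3cc(C)no3)c(=O)[nH]c2=O)C[C@@H]1OC(C)=O`), which in this assay gives 106%.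

All three numbers describe how strongly a single concentration holds back the growth of the breast cancer cells, so a higher number means more inhibition in this assay. Compound 3 stands level with compound 1 at the digits shown, and the two together are the highest of the three; the value of compound 2 sits only within the usual scatter of that of compound 3, so no real difference between them can be claimed.

Compound 4 (`CC(=O)OC[C@H]1O[C@@H](n2cc(-c3cc(-c4ccccc4)no3)c(=O)[nH]c2=O)C[C@@H]1OC(C)=O`) differs from compound 3 in one place: phenyl in place of methyl on an aromatic carbon Put another way, 3-methyl-1,2-oxazol-5-yl becomes 3-phenyl-1,2-oxazol-5-yl.

Within the data shown here, no pair of measured compounds shows a single-point step, so there is no measured guide for this change. Because compound 3 already gives 106%, a number near the top of the range seen here, the step of a number 6 percentage points lower from compound 3 to compound 4 (within the scatter) is expected to stay within the scatter, with little room for a higher reading. Compound 4 is therefore expected to give about 100% in this assay, between 80% and 110%.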

Compound 4, a percentage reported as inhibition, at one concentration (the size of the read-out at that concentration, not a potency): 95%
Beside the measured number, compound 4's estimate is 5 percentage points above it; measured number inside the range.
By their numbers in this assay, from the lowest: compounds 4, 2, 1 and 3 (each within the scatter of the next, the first and the last beyond it).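

Among these compounds, this is the first single-point step in this assay: on the aromatic carbon next to the ring nitrogen, putting phenyl in place of methyl gives a number 11 percentage points lower from compound 3 to compound 4 (beyond the scatter) in the reading, a modest change. The position therefore responds to the group placed on it, yet with the larger group compound 4 at 95% still shows strong inhibition at the one concentration tested. No measured evidence here bears on what lies behind this drop.

Open, as far as these compounds go, is how this position would respond to groups of another kind, such as an amine, a carboxylic acid or a methoxy group, rather than to a larger carbon ring. Also open, from the compounds shown here alone, is whether the same swap of methyl for phenyl would shift the reading similarly on a core with free hydroxyl groups instead of acetate esters.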